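The source may hold more compounds than are shown below. What is called first, only, known or untested is meant among the compounds shown, and "the series" means these compounds.

Within the data shown here, in a functional assay on MDA-MB-231 cells (Homo sapiens) for inhibition (a higher number here means a weaker inhibitor, a lower number a stronger inhibitor), compound 2, `O=C1C=CC(OCC(F)(F)F)N1c1ccc([N+](=O)[O-])cc1`, gives 2830 nM, the lowest of the two numbers measured so far. Its nearest neighbour is compound 1, `Cc1ccc(N2C(=O)C=CC2OCC(F)(F)F)cc1`, which in this assay gives 15800 nM. The two differ only in one group on the aromatic ring, and the shift is a 5.6-fold lower number from compound 1 to compound 2 (0.75 log units; beyond the scatter).

Compound 3, `CC(C)(C)c1ccc(N2C(=O)C=CC2OCC(F)(F)F)cc1`, has not yet been measured. Compared with compound 2 the change is tert-butyl in place of nitro on an aromatic carbon. Among the measured compounds shown here, the only step that bears on this is the one from compound 1 to compound 2, where a nitro replaced a methyl and the number fell beyond the scatter. Compound 3 goes the other way: the nitro leaves and an alkyl group, tert-butyl, enters in its place. The tert-butyl is not identical to the methyl of compound 1, so the reversal need not be exact, but the direction is expected to be upward, back toward the number of compound 1.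

For compound 3 in this assay the expected step is a 4.2-fold higher number from compound 2 to compound 3 (0.63 log units; beyond the scatter), giving an estimate of 12000 nM with a range from 4000 nM to 40000 nM.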

Compound 3, half-maximal inhibitory concentration: 1860 nM
Estimate against measurement, compound 3: 6.5-fold (0.81 log units) above; measured number below the stated range.
By their numbers in this assay, from the lowest: compounds 3 and 2 (each within the scatter of the next); then compound 1.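

In this assay the swap of nitro for tert-butyl gives a 1.5-fold lower number from compound 2 to compound 3 (0.18 log units; within the scatter) and so leaves the two groups indistinguishable here, even though nitro carries nitrogen, oxygen and hydrogen-bond acceptors while tert-butyl carries only carbon and no acceptors. The low number at this place on the ring is therefore not tied to nitro, and an alkyl group in this place does not by itself bring the number back up, since the change from methyl to tert-butyl gives an 8.5-fold lower number from compound 1 to compound 3 (0.93 log units; beyond the scatter) and is as clear as the earlier step from methyl to nitro. No measurement at hand explains why methyl stands apart from the other two groups.

Among these compounds, with only three groups at one place on the ring, it remains open whether the low number depends on the size of the group, on something else, or on both. An amine, a carboxylic acid, a halogen such as chlorine or a longer alkyl chain in the same place could help separate these possibilities, and each could show whether the number falls further or climbs back.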